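A few compounds are considered here, and "the series" means these few. Any claim that something is new, unique, unknown or untested is made for them only; others in the source may bear on it.

compound 1 `OCC1CCN(c2nccnc2Oc2ccc(Nc3nc4ccccc4s3)cc2)CC1` — 8 10^-6 cm/s
compound 2 `OCC1CCN(c2nccnc2Oc2ccc(Nc3nc4ccccc4[nH]3)cc2)CC1` — 41.6 10^-6 cm/s

In an ADME assay on LLC-PK1 cells (Sus scrofa) for permeability, read by LC-MS, with a stated time of 2 h, tested at 5 uM (a higher number here means that the compound crosses the layer faster, a lower number that the compound crosses the layer more slowly), compound 2 gives 41.6 10^-6 cm/s, the higher of the two numbers, while compound 1 gives 8 10^-6 cm/s. Among the compounds with values here, the one measured step, a 5.2-fold higher number from compound 1 to compound 2 (0.72 log units; beyond the scatter), concerns a different exchange and does not bear directly on the change now in view. Compound 3 `Cn1c(Nc2ccc(Oc3nccnc3N3CCC(CO)CC3)cc2)nc2ccccc21` differs from compound 2 by methyl in place of hydrogen on an aromatic nitrogen. Within the data shown here, with no step in the set informing on this change, the expected step of a 1.1-fold higher number from compound 2 to compound 3 (0.03 log units; within the scatter) is none beyond the scatter. Compound 3 is therefore estimated at 45 10^-6 cm/s, within 20 10^-6 cm/s to 90 10^-6 cm/s.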

Compound 3, apparent permeability: 39.4 10^-6 cm/s
Beside the measured number, compound 3's estimate is 1.1-fold (0.06 log units) above it; measured number inside the range.
By their numbers in this assay, from the lowest: compound 1; then compounds 3 and 2 (each within the scatter of the next).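

Putting methyl on the aromatic nitrogen leaves the reading in this assay level with that of the parent (a 1.1-fold lower number from compound 2 to compound 3 (0.02 log units; within the scatter)). The hydrogen on this nitrogen is therefore not required for the higher number, and the 1-methyl-1H-benzimidazol-2-yl compound stays clear of the 1,3-benzothiazol-2-yl one (a 4.9-fold higher number from compound 1 to compound 3 (0.69 log units; beyond the scatter)). No evidence at hand bears on this result. From the compounds shown here alone, whether an ethyl group or a longer chain on this nitrogen would hold the number stays open, and so does the outcome with a chain ending in an amine or a carboxylic acid.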